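Chloro in place of methoxy: what to expect of compound 3

A few compounds are considered here, and "the series" means these few. Any claim that something is new, unique, unknown or untested is made for them only; others in the source may bear on it.

Of the compounds shown here, two sharing one core have been measured in a functional assay on HeLa cells (Homo sapiens) for cytotoxicity, read by MTT assay, with a stated time of 48 h; a lower number here means a stronger inhibitor, a higher number a weaker inhibitor. There, compound 1 `COc1ccc(-c2nc3ccccn3c2C(=O)/C=C\Nc2cnc3ccccc3c2)cc1` gives 9440 nM and compound 2 `COc1ccc(-c2nc3ccccn3c2C(=O)/C=C\Nc2ccc3ncccc3c2)cc1` gives 4850 nM. These values lie within the scatter of each other, so compound 2 cannot be ranked against compound 1. Compound 3 `O=C(/C=C\Nc1ccc2ncccc2c1)c1c(-c2ccc(Cl)cc2)nc2ccccn12` keeps the quinolin-6-yl group of compound 2 on the amine nitrogen but carries a different aryl substituent: chloro in place of methoxy on an aromatic carbon. In words, 4-methoxyphenyl becomes 4-chlorophenyl, with chloro in place of methoxy on an aromatic carbon, para to a large group. Among the measured compounds shown here, the only measured step, a 1.9-fold lower number from compound 1 to compound 2 (0.29 log units; within the scatter), concerns the group on the amine nitrogen and stays within the scatter. For the measured compounds named here, no measured step touches the methoxy group, so the data offer no guide to the direction of this change, and no step beyond the scatter is expected. For compound 3 the expected value is 5000 nM, with an estimated range of 1800 nM to 14000 nM. This estimate means an expected 1.0-fold higher number from compound 2 to compound 3 (0.01 log units; within the scatter).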

Compound 3, half-maximal inhibitory concentration: 16400 nM
Compound 3: the middle estimate sits 3.3-fold (0.52 log units) below what was measured; the whole stated range lies below it.
By their numbers in this assay, from the lowest: compounds 2, 1 and 3 (each within the scatter of the next, the first and the last beyond it).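

In this assay, 4-chlorophenyl in place of 4-methoxyphenyl, with the quinolin-6-yl group unchanged, gives a 3.4-fold higher number from compound 2 to compound 3 (0.53 log units; beyond the scatter) and is the first step among these compounds to lie beyond the scatter. The earlier step changed only the group on the amine nitrogen and said nothing about the aryl substituent, whereas this pair shows that the substituent on an aromatic carbon, para to a large group, can separate two compounds in this read-out, with methoxy giving the lower number of the two, though the step is modest. The compounds shown offer no measurement that accounts for this difference between chloro and methoxy.

On these data alone, what remains open is whether the higher number reflects the arrival of chloro or the departure of methoxy, a question that a plain phenyl group, or a fluoro or hydroxy group in place of methoxy, would help to answer. As far as these compounds go, whether the same change holds with quinolin-3-yl on the amine nitrogen, as in compound 1, also stays open.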